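This account rests on a few compounds, and the source may have more. Where it says the series, first, only, none or still open, it means among the compounds named here.

Measured compounds:
Compound 1 `CC(C)c1c(C(=O)NCc2ccccc2)nn(-c2ccc(F)cc2)c1OC[C@@H](O)C[C@@H](O)CC(=O)O` gives 3.8 nM in an assay on microsomes from liver for inhibition of 3-hydroxy-3-methylglutaryl-coenzyme A reductase (Rattus norvegicus); a lower number here means a stronger inhibitor, a higher number a weaker inhibitor.
Compound 2 `CC(C)c1c(C(=O)N2CCCC2c2ccccc2)nn(-c2ccc(F)cc2)c1OC[C@@H](O)C[C@@H](O)CC(=O)O` gives 14 nM in this assay.
Compound 3 `CC(C)c1c(C(=O)N2CCCCC2)nn(-c2ccc(F)cc2)c1OC[C@@H](O)C[C@@H](O)CC(=O)O` gives 47 nM in this assay.

Compound 3 stands at the highest number of the three, so it is the weakest inhibitor in this set: the step of a 12-fold higher number from compound 1 to compound 3 (1.09 log units; beyond the scatter) is large and the step of a 3.4-fold higher number from compound 2 to compound 3 (0.53 log units; beyond the scatter) is modest, and both lie beyond the scatter. Compound 4 `CC(C)c1c(C(=O)NCc2ccccc2Cl)nn(-c2ccc(F)cc2)c1OC[C@@H](O)C[C@@H](O)CC(=O)O` differs from compound 3 in one place: (2-chlorobenzyl)amino in place of piperidin-1-yl on a carbonyl carbon. The step that bears most directly on this change is a 12-fold higher number from compound 1 to compound 3 (1.09 log units; beyond the scatter), where a benzylamino group gave way to a piperidin-1-yl; compound 4 runs that exchange backwards, with a (2-chlorobenzyl)amino group standing in for the plain benzylamino of compound 1. Among the compounds with values here, no measured pair shows what the chlorine itself does, so that part stays open. A large fall in this assay is therefore expected, roughly undoing the rise seen toward compound 3; the expected step is a 12-fold lower number from compound 3 to compound 4 (1.07 log units; beyond the scatter). Compound 4 is estimated at 4 nM, most likely between 1.5 nM and 12 nM.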

Compound 4, half-maximal inhibitory concentration: 9.5 nM
Beside the measured number, compound 4's estimate is 2.4-fold (0.38 log units) below it; the measured number falls inside the stated range.
By their numbers in this assay, from the lowest: compound 1; then compounds 4 and 2 (each within the scatter of the next); then compound 3.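

In this assay, the chlorine can now be read on its own: chloro in place of hydrogen on an aromatic carbon gives a 2.5-fold higher number from compound 1 to compound 4 (0.40 log units; beyond the scatter), so this substitution on the benzylamino group does not add to inhibition. The (2-chlorobenzyl)amino group still outperforms piperidin-1-yl, with a 4.9-fold lower number from compound 3 to compound 4 (0.69 log units; beyond the scatter), while a 1.5-fold lower number from compound 2 to compound 4 (0.17 log units; within the scatter) leaves it level with 2-phenylpyrrolidin-1-yl. No measurement is available to explain these differences.

On these data alone, it remains open whether the result is specific to chlorine or to its place on the ring, which (3-chlorobenzyl)amino, (4-chlorobenzyl)amino or (2-fluorobenzyl)amino groups could test. A methyl group in place of the amide hydrogen of compound 1 would show whether that hydrogen matters for the advantage of benzylamino over piperidin-1-yl.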